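The source may report more compounds than this note shows. Statements on the series, on what has been measured and on what is new or still open speak of the compounds shown alone.

Measured compounds in a functional assay on HEK293 cells (Homo sapiens) for cytotoxicity; on this read-out lower numbers stand for higher toxicity in this test and higher numbers for lower toxicity in this test:
compound 1 `COc1ccc([C@H]2CC(=O)N(C(C)=O)C2)cc1OC1CCCC1`: > 10000 nM
compound 2 `COc1ccc([C@H]2CC(=O)N(c3cccc(C#N)c3)C2)cc1OC1CCCC1`: > 10000 nM
compound 3 `COc1ccc([C@H]2CC(=O)N(c3ccccn3)C2)cc1OC1CCCC1`: > 10000 nM

In this assay compound 2 gives > 10000 nM, which is a limit of the assay and not a number. Compound 1 likewise reaches only a limit, > 10000 nM. Compound 3 also stops at a limit, > 10000 nM. All three sit at the limit of > 10000 nM in this assay, at which 3 of the 3 values shown sit, so the steps a step that the two limits leave unreadable from compound 1 to compound 2, a step that the two limits leave unreadable from compound 1 to compound 3 and a step that the two limits leave unreadable from compound 2 to compound 3 cannot be sized. Compound 4 `COc1ccc([C@H]2CC(=O)N(c3cccc(NS(=O)(=O)c4cccc(Cl)c4)c3)C2)cc1OC1CCCC1` differs from compound 2 by ((3-chlorophenyl)sulfonyl)amino in place of cyano on an aromatic carbon. Among the measured compounds shown here, no measured step reads on this change, so no direction can be drawn from the data. Compound 4 is therefore expected to give 10000 nM, within 3000 nM to 30000 nM, and the expected step is a number no higher from compound 2 to compound 4 (the limit leaves the size open), most likely again a limit.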

Compound 4, half-maximal cytotoxic concentration: > 10000 nM
Compound 4: only a limit was reported; the forecaster's own chance of this, stated with the estimate: 60%; the middle value lies on the limit itself.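

Compound 4, like compound 2, stops at a limit of the assay, so the step between these two compounds cannot be read. The compounds shown leave open whether any of these changes shifts the half-maximal cytotoxic concentration at all: the limit of > 10000 nM in this assay, at which 4 of the 4 values shown sit.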